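The source may hold more compounds than are shown below. What is called first, only, known or untested is meant among the compounds shown, and "the series" means these compounds.

Compound 1 `Cc1cc(Nc2cc(-c3cccs3)[nH]n2)n2nc(SCc3ccc(Br)cc3)nc2n1` gives 5370 nM
Compound 2 `Cc1cc(Nc2cc(-c3ccccc3)[nH]n2)n2nc(SCc3ccc([N+](=O)[O-])cc3)nc2n1` gives 5060 nM
Compound 3 `CCCCCc1c(C)nc2nc(SCc3ccc(Cl)cc3)nn2c1Nc1cc(-c2ccccc2)[nH]n1` gives 6390 nM

In a functional assay on MCF7 cells (Homo sapiens) for inhibition, read by MTT assay, with a stated time of 72 h (a lower number here means a stronger inhibitor, a higher number a weaker inhibitor), these three numbers lie within the usual scatter of one another, so compound 2 stands level with compound 1 and compound 3, and no order can be drawn among them.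

Compound 4 `C#CCSc1nc2nc(C)cc(Nc3cc(-c4ccccc4)[nH]n3)n2n1` has not yet been measured. It differs from compound 2 in one place, with ethynyl in place of 4-nitrophenyl on a saturated chain carbon bound to a sulfur. Cut one bond further out, the same difference reads 4-nitrobenzyl to propargyl. One six-membered aromatic ring of carbon only leaves, and no ring enters.

Going by the values given here, no two measured compounds differ in one place only, and none carries ethynyl in this place, so the data give no direct size for such a change. Among the compounds with values here, the only anchor is compound 2 at 5060 nM as the starting point. A modest move toward weaker inhibition is expected, though it may not clear the scatter by much. The expected size is an estimated 1.8-fold higher number from compound 2 to compound 4 (0.25 log units; within the scatter) in that direction, with wide uncertainty. Compound 4 is expected at 9000 nM within a range of 3500 nM to 30000 nM as an estimate.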

Compound 4, half-maximal inhibitory concentration: 21800 nM
Estimate against measurement, compound 4: 2.4-fold (0.38 log units) below; low and high end bracket the measured number.
By their numbers in this assay, from the lowest: compounds 2, 1 and 3 (each within the scatter of the next); then compound 4.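

In this assay, putting ethynyl in place of 4-nitrophenyl on a saturated chain carbon bound to a sulfur gives a 4.3-fold higher number from compound 2 to compound 4 (0.63 log units; beyond the scatter), a modest step beyond the scatter and the first change in a single place that can be read among these compounds. It shows that this position is not indifferent to what it carries: going from 4-nitrobenzyl to propargyl, with the six-membered aromatic ring of carbon only leaving and no ring entering, comes with weaker inhibition while the rest of the molecule stays the same. Nothing at hand gives a reason for this step.

The compounds shown leave open whether the step follows the ring or the nitro group, a question that an unsubstituted benzyl group on the same sulfur, or a plain propyl or longer alkyl chain, would bear on. Compound 1 and compound 3 carry halogen-bearing benzyl groups here but also differ from compound 2 elsewhere, so they cannot settle how far the ring alone matters at this position.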